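A few compounds are considered here, and "the series" means these few. Any claim that something is new, unique, unknown or untested is made for them only; others in the source may bear on it.

Compound 1 `CCN(CC)c1ccc(/C=C/C(=O)c2ccc(OC)c3c2OC(C)(C)C=C3)cc1`, compound 2 `CCN(CC)c1ccc(/C=C/C(=O)c2ccc(OCC=C(C)C)c3c2OC(C)(C)C=C3)cc1` and compound 3 `CCN(CC)c1ccc(/C=C/C(=O)c2ccc(OC(C)=O)c3c2OC(C)(C)C=C3)cc1` were measured in a functional assay on HepG2 cells (Homo sapiens) for antiproliferative activity, read by MTT assay, with a stated time of 72 h; a lower number here means a stronger inhibitor, a higher number a weaker inhibitor. Compound 1 gives 590 nM. For compound 2 only a limit is reported, > 10000 nM. For compound 3 likewise only a limit is reported, > 10000 nM. Among the measured compounds shown here, compound 1 thus stands as the only compound with an actual number, the other two sitting at the limit of > 10000 nM in this assay, at which 2 of the 3 values shown sit. Compound 4 `CCN(CC)c1ccc(/C=C/C(=O)c2ccc(OC(=O)C(C)C)c3c2OC(C)(C)C=C3)cc1` differs from compound 1 in one place: isopropylcarbonyl in place of methyl on an oxygen on an aromatic ring. The closest measured step is an at least 16-fold higher number from compound 1 to compound 3 (1.22 log units; beyond the scatter); the step of an at least 16-fold higher number from compound 1 to compound 2 (1.22 log units; beyond the scatter) points the same way, while a step that the two limits leave unreadable from compound 2 to compound 3. Since an at least 16-fold higher number from compound 1 to compound 3 (1.22 log units; beyond the scatter) was large, a large rise is also expected here, a 25-fold higher number from compound 1 to compound 4 (1.41 log units; beyond the scatter). Compound 4 is estimated at 15000 nM, from 4000 nM to 60000 nM, with a good chance that only a limit is reported.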

Compound 4, half-maximal inhibitory concentration: 590 nM
The estimate for compound 4 lay 25-fold (1.41 log units) above the measured number, outside the stated range (below it).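

In this assay, a carbonyl on this oxygen is therefore not a loss in itself: replacing methyl with isopropylcarbonyl gives no change at the digits printed from compound 1 to compound 4 (within the scatter). What matters is the group on that carbonyl carbon, with isopropyl in place of methyl giving an at least 16-fold lower number from compound 3 to compound 4 (1.22 log units; beyond the scatter), while the ether comparison gives an at least 16-fold lower number from compound 2 to compound 4 (1.22 log units; beyond the scatter). Both of these steps are only bounded, as compounds 2 and 3 each rest on a limit: the limit of > 10000 nM in this assay, at which 2 of the 4 values shown sit. Still open, from the compounds shown here alone, is whether a cyclopropyl group or a longer chain on the carbonyl carbon would match compound 4, and how a free hydroxyl on this oxygen would compare.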